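Swapping a Phenoxy Group for Dimethylamino on the Pyrazole Series

The compounds below may be only part of what the source reports. "The series", "measured", "known", "first", "only" and "open" are said of these compounds alone.

Of the compounds shown here, three have been measured in a functional assay on SW-620 cells (Homo sapiens) for cytotoxicity, read by sulforhodamine B assay, with a stated time of 48 h, tested at 100 nM; on this read-out higher numbers stand for a weaker effect at the one concentration tested and lower numbers for a stronger effect. Compound 1 `COc1cc(C)cc(-c2c(-c3ccnc(-c4ccc(C(C)=O)cc4)c3)cnn2CC#N)c1` gives 71%, and compound 2 `COc1cc(C)cc(-c2nn(CC#N)cc2-c2ccc(-c3cccc(C(C)=O)c3)nc2)c1` gives 56%. Compound 3 `Cc1cc(O)cc(-c2nn(CC#N)cc2-c2ccnc(-c3ccc(Oc4ccccc4)cc3)c2)c1` gives 92%, the highest of the three numbers and therefore the weakest effect seen so far; its gaps to compound 1 and to compound 2 both lie beyond the scatter.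

The next compound, compound 4 `Cc1cc(O)cc(-c2nn(CC#N)cc2-c2ccnc(-c3ccc(N(C)C)cc3)c2)c1`, keeps the whole frame of compound 3 and changes one group: dimethylamino in place of phenoxy on an aromatic carbon. Among the compounds with values here, no pair of measured compounds differs in exactly this way, so the size of the step has no direct precedent in the data.

Because compound 3 stands at 92%, there is more room for the number to fall than to rise. The expectation is a modest step toward a lower number, possibly not beyond the scatter, expressed as a number 10 percentage points lower from compound 3 to compound 4 (within the scatter). Compound 4 is therefore estimated at 82%, with a range from 60% to 100%.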

Compound 4, a percentage reported as activity, at one concentration (the size of the read-out at that concentration, not a potency): 83%
Beside the measured number, compound 4's estimate is 1 percentage points below it; measured number inside the range.
By their numbers in this assay, from the lowest: compound 2; then compound 1; then compounds 4 and 3 (each within the scatter of the next).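

In this assay, putting dimethylamino in place of phenoxy on an aromatic carbon gives a number 9 percentage points lower from compound 3 to compound 4 (within the scatter). Within the data shown here, this is the first single-place comparison, and it shows that at this position, para to a large group, the six-membered aromatic ring of phenoxy can be exchanged for a group with no ring without the read-out leaving the usual scatter. No measurement at hand explains this outcome.

The shown compounds leave open whether any group at this position can move the read-out beyond the scatter, since this is the only change tested here. A morpholine ring or a carboxylic acid in the same place would test that, while compound 1 and compound 2 differ from compound 4 in more than one place and cannot settle it.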